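Chloro for methoxy in the antiproliferative series: second pass

The source may hold more compounds than are shown below. What is called first, only, known or untested is meant among the compounds shown, and "the series" means these compounds.

Compound 2 `COc1ncc(-c2ccc3nc(NC(C)=O)nn3c2)cc1NS(=O)(=O)c1ccc(C)cc1` and compound 1 `CC(=O)Nc1nc2ccc(-c3cnc(Cl)c(NS(=O)(=O)c4ccc(C)cc4)c3)cn2n1` differ in one place. In a functional assay on U-87MG ATCC cells (Homo sapiens) for antiproliferative activity, read by MTT assay, with a stated time of 48 h (on this read-out higher numbers stand for weaker inhibition and lower numbers for stronger inhibition), compound 2 gives 1600 nM and compound 1 gives 3760 nM. The difference is chloro in place of methoxy on an aromatic carbon and the step it made is a 2.4-fold higher number from compound 2 to compound 1 (0.37 log units; beyond the scatter).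

Compound 3 `COc1ncc(-c2ccc3nc(NC(=O)C4CC4)nn3c2)cc1NS(=O)(=O)c1ccc(F)cc1` gives 4850 nM in this assay; the difference between the cores of compound 3 and compound 2 is not broken down here. Compound 4 `O=C(Nc1nc2ccc(-c3cnc(Cl)c(NS(=O)(=O)c4ccc(F)cc4)c3)cn2n1)C1CC1` is compound 3 carrying (chloro in place of methoxy on an aromatic carbon). This is the same kind of change as from compound 2 to compound 1, though here the place is ortho to a ((4-fluorophenyl)sulfonyl)amino group rather than ortho to a large group. Going by the values given here, the step of a 2.2-fold higher number from compound 3 to compound 4 (0.34 log units; beyond the scatter) is expected to resemble the earlier one because a 2.4-fold higher number from compound 2 to compound 1 (0.37 log units; beyond the scatter) is the only measured instance of this change. Compound 4 is therefore estimated at 10500 nM in this assay, within 4500 nM to 25000 nM.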

Compound 4, half-maximal inhibitory concentration: 11000 nM
Compound 4: middle estimate off by 1.0-fold (0.02 log units), on the low side; measured number inside the range.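

In this assay, chloro in place of methoxy gave a 2.3-fold higher number from compound 3 to compound 4 (0.36 log units; beyond the scatter), matching the earlier step on the other core: the same change on two cores in this assay, a 2.4-fold higher number (0.37 log units; beyond the scatter) from compound 2 to compound 1 and a 2.3-fold higher number (0.36 log units; beyond the scatter) from compound 3 to compound 4, 1.0-fold (0.02 log units) apart, within the scatter of two such steps Within this series, the change therefore carried over between the core of compound 2 and the core of compound 3 in both direction and size, with weaker inhibition each time. These two pairs do not show why the change has this effect, or that the step would hold on any further core.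

The compounds shown leave open how an amine or an ethoxy group would read in the place of methoxy or chloro. They also leave open how the separate differences between the core of compound 2 and the core of compound 3 each affect the read-out.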